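Tert-butoxy for tert-butyl on the carbonyl carbon

A few compounds are considered here, and "the series" means these few. Any claim that something is new, unique, unknown or untested is made for them only; others in the source may bear on it.

Two compounds in the series have readings so far: compound 1 (`FC(F)(F)c1cccc(NN=C2C(Cl)=C(Cl)C(Cl)=C2Cl)c1`) and compound 2 (`CC(C)(C)C(=O)NN=C1C(Cl)=C(Cl)C(Cl)=C1Cl`). In an ADME assay on PBL cells for cytotoxicity, read by MTT assay, with a stated time of 48 h (a lower number here means a stronger inhibitor, a higher number a weaker inhibitor), compound 1 gives 15000 nM as its reading, while compound 2 gives 1250 nM as its reading. Compound 2 therefore holds the lower of the two numbers, and the gap lies beyond the usual scatter.

Compound 3 (`CC(C)(C)OC(=O)NN=C1C(Cl)=C(Cl)C(Cl)=C1Cl`) carries tert-butoxy in place of tert-butyl on a carbonyl carbon. Among the measured compounds shown here, no measured pair shows this change, so the expectation starts from compound 2 at 1250 nM and has no direct precedent. A small step toward a higher number, not beyond the scatter, is expected (a 1.3-fold higher number from compound 2 to compound 3 (0.11 log units; within the scatter)). Compound 3 is expected at 1600 nM within an estimated range of 550 nM to 4700 nM in this assay once measured.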

Compound 3, half-maximal inhibitory concentration: 5000 nM
Estimate against measurement, compound 3: 3.1-fold (0.49 log units) below; measured number above the stated range.
By their numbers in this assay, from the lowest: compound 2; then compound 3; then compound 1.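

In this assay, among the compounds shown here, replacing tert-butyl with tert-butoxy on a carbonyl carbon whose other neighbours are an amide-type nitrogen gives a 4.0-fold higher number from compound 2 to compound 3 (0.60 log units; beyond the scatter), the first comparison that differs in one place. For the compounds shown here, the oxygen brought in by tert-butoxy is the only change in heavy atoms, so this position does not tolerate that insertion without a shift beyond the scatter, and the shift runs toward a higher number. No measurement on hand accounts for this shift.

Still open, as far as these compounds go, is how this carbonyl carbon responds to other groups, such as a longer straight chain, a phenyl ring or a dimethylamino group. Also open, from the compounds shown here alone, is whether the same change from tert-butyl to tert-butoxy would give a step of similar size on a different core.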